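This account rests on a few compounds, and the source may have more. Where it says the series, first, only, none or still open, it means among the compounds named here.

In an assay on membranes from brain for binding affinity to neutral cholesterol ester hydrolase 1 (Mus musculus), read by fluorescence, with stated times of 1 h and 30 min (a higher number here means a weaker inhibitor, a lower number a stronger inhibitor), compound 1, with the structure `N#Cc1cnn(C(=O)N2CCCN(Cc3ccc(OCc4ccccc4)cc3)CC2)c1`, gives only a limit of the assay, > 100000 nM, and no number. Compound 2, with the structure `Cc1cnn(C(=O)N(C)CCN(C)C(c2ccc(OCc3ccccc3)cc2)c2ccc(OCc3ccccc3)cc2)c1`, stands in this assay at a limit as well, > 1000000 nM, so nothing places it on a measured scale. Going by the values given here, both values therefore sit at limits, as the limit of > 100000 nM in this assay, at which 1 of the 2 values shown sits, and the limit of > 1000000 nM in this assay, at which 1 of the 2 values shown sits, record, and no measured step between them exists. Compound 3, with the structure `CN(CCN(C)C(c1ccc(OCc2ccccc2)cc1)c1ccc(OCc2ccccc2)cc1)C(=O)n1cc(C#N)cn1`, differs from compound 2 by cyano in place of methyl on an aromatic carbon. The cyano-bearing five-membered ring is also present in compound 1, which reached no number in this assay. The step of an at least 2.0-fold lower number from compound 2 to compound 3 (0.30 log units; that floor lies within the scatter) is therefore expected to be none beyond the scatter, with no measurable gain. For compound 3 the expected value in this assay is 500000 nM, within a range from 100000 nM to 3000000 nM.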

Compound 3, half-maximal inhibitory concentration: > 1000000 nM
Compound 3: a limit, no number (the forecaster's own chance of this, stated with the estimate: 85%); at least 2.0-fold (0.30 log units) between middle value and limit.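

Going by these compounds alone, compound 2 and compound 3 both sit at a limit of the assay and give no number, so no step between them can be read. Whether cyano in place of methyl shifts inhibition at all stays open: none of the three compounds shown gives a measured number.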